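Hydroxy to Amino on the Hydroxamate Side Chain

The source may hold more compounds than are shown below. What is called first, only, known or untested is meant among the compounds shown, and "the series" means these compounds.

Compound 1, `O=C(N[C@@H](CO)C(=O)NO)c1ccc(C#Cc2ccccc2)cc1`: 2
Compound 2, `O=C(NC1(C(=O)NO)CCNCC1)c1ccc(C#Cc2ccccc2)cc1`: 3
Compound 3, `O=C(NC1(C(=O)NO)CCN(Cc2ccccc2)CC1)c1ccc(C#Cc2ccccc2)cc1`: > 3

In a physicochemical assay for lipophilicity (on this read-out higher numbers stand for higher lipophilicity and lower numbers for lower lipophilicity), compound 1 gives 2, the lowest of the two numbers shown, with compound 2 a full step higher, beyond the scatter. For compound 3 the assay reports only a limit, > 3, not a number. Among the measured compounds shown here, the one measured step, a number no lower from compound 2 to compound 3 (the limit leaves the size open), adds a benzyl and does not touch a hydroxy. Compound 4, `NC[C@H](NC(=O)c1ccc(C#Cc2ccccc2)cc1)C(=O)NO`, differs from compound 1 by amino in place of hydroxy on a saturated chain carbon, two bonds along the chain from an amide-type nitrogen and a carbonyl carbon. For the measured compounds named here, no measured step bears on this change, so the expectation rests on compound 1 alone and carries a wide range. Compound 4 is expected to give 1, between 0 and 2, an estimated step of a number 1.00 log units lower from compound 1 to compound 4 (beyond the scatter).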

Compound 4, distribution coefficient: 2
Beside the measured number, compound 4's estimate is 1.00 log units below it; the measured number falls inside the stated range.
By their numbers in this assay, from the lowest: compounds 1 and 4 (each within the scatter of the next); then compound 2.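

Amino in place of hydroxy on this saturated chain carbon is the only step shown at this position, and in this assay it gives no change at the digits printed from compound 1 to compound 4 (within the scatter). Among the compounds shown here, on this read-out, then, hydroxymethyl and aminomethyl cannot be told apart here, a result the earlier compounds could not show. Nothing shown accounts for this outcome. Going by these compounds, whether a carboxylic acid, a methoxy group or an amine on a longer chain would read the same at this position stays open.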